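This account rests on a few compounds, and the source may have more. Where it says the series, first, only, none or still open, it means among the compounds named here.

Measured in a functional assay (aorta) with Rattus norvegicus as the target; a higher number here means that more compound is needed for the effect, a lower number that less compound is needed:
- compound 1 `COc1ccc(-c2nc(CNC(=O)CSC)sc2-c2ccc(OC)cc2)cc1`: 6 uM
- compound 2 `COc1ccc(-c2nc(CNC(=O)N3CCOCC3)sc2-c2ccc(OC)cc2)cc1`: 12 uM

Among the compounds with values here, with only two numbers in hand, compound 2 stands level with compound 1, as the only measured step shows: a 2.0-fold higher number from compound 1 to compound 2 (0.30 log units; within the scatter). Compound 3 `CCN(CC)C(=O)c1nc(-c2ccc(OC)cc2)c(-c2ccc(OC)cc2)s1` is not yet measured, and its change is diethylcarbamoyl in place of (((morpholin-4-yl)carbonyl)amino)methyl on an aromatic carbon. The measured step bears on this only loosely, since it swaps the group on a carbonyl carbon and leaves untouched what joins that carbonyl to the shared core. The data therefore give no sign of a large shift, though the range stays wide. The expected step in this assay is a 1.2-fold lower number from compound 2 to compound 3 (0.08 log units; within the scatter), none beyond the scatter. For compound 3 the estimate is 10 uM, with an expected range of 3 uM to 35 uM.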

Compound 3, concentration for half-maximal effect: 14 uM
The estimate for compound 3 lay 1.4-fold (0.15 log units) below the measured number, within the range that was stated.
By their numbers in this assay, from the lowest: compounds 1, 2 and 3 (each within the scatter of the next, the first and the last beyond it).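

Putting diethylcarbamoyl in place of the (((morpholin-4-yl)carbonyl)amino)methyl on the aromatic carbon changes the whole arm, not just the group on the carbonyl, and in this assay gives a 1.2-fold higher number from compound 2 to compound 3 (0.07 log units; within the scatter), so a shorter arm with no ring and no hydrogen-bond donor still stays level with compound 2. Set against the arm of compound 1, the same group gives a 2.3-fold higher number from compound 1 to compound 3 (0.37 log units; beyond the scatter), the only step so far beyond the scatter. No measurement here accounts for either step. Going by these compounds, whether a carboxylic acid or a basic amine on this aromatic carbon would move the number beyond the scatter remains open. So does the effect of longer chains in place of the two ethyl groups.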